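The source may hold more compounds than are shown below. What is called first, only, known or untested is meant among the compounds shown, and "the series" means these compounds.

Measured compounds in a functional assay on NCI/ADR-RES cells (Homo sapiens) for inhibition; on this read-out lower numbers stand for stronger inhibition of growth and higher numbers for weaker inhibition of growth:

compound 1 `COc1cc(/C=C/C(=O)c2cccc(-n3cc(-c4ccc(Cl)cc4)[nH]c3=O)c2)cc(OC)c1OC` — 2360 nM
compound 2 `COc1ccc(-c2cn(-c3cccc(C(=O)/C=C/c4cc(OC)c(OC)c(OC)c4)c3)c(=O)[nH]2)cc1` — 1700 nM

Among the compounds with values here, compound 2 gives the lowest of the two numbers in this assay, but its only neighbour, compound 1, sits within the scatter of it, so no order between the two can be read. Within the data shown here, the single measured step, a 1.4-fold lower number from compound 1 to compound 2 (0.14 log units; within the scatter), exchanges one substituent on the pendant phenyl ring for another and moves the number by an amount that does not stand out from repeat measurements.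

Compound 3 `COc1cc(/C=C/C(=O)c2cccc(-n3cc(-c4cc(OC)c(OC)c(OC)c4)[nH]c3=O)c2)cc(OC)c1OC` carries the change (3,4,5-trimethoxyphenyl in place of 4-methoxyphenyl on an aromatic carbon). Among the measured compounds shown here, it touches the same pendant phenyl ring as the measured step, which is the only reason that step bears on it at all; the addition of two further methoxy groups on that ring has no measured counterpart. For the measured compounds named here, with the one relevant step within the scatter, the expectation for this assay is a step of no clear size in either direction, and the uncertainty is taken wide. Compound 3 is expected near 1500 nM, with a range from 500 nM to 4500 nM. That estimate corresponds to a 1.1-fold lower number from compound 2 to compound 3 (0.05 log units; within the scatter).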

Compound 3, concentration for 50% growth inhibition: 2100 nM
For compound 3 the middle estimate is 1.4-fold (0.15 log units) below the measured one; measured number inside the range.
By their numbers in this assay, from the lowest: compounds 2, 3 and 1 (each within the scatter of the next).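

In this assay, adding two further methoxy groups to the pendant phenyl ring gives a 1.2-fold higher number from compound 2 to compound 3 (0.09 log units; within the scatter), and replacing 4-chlorophenyl with 3,4,5-trimethoxyphenyl gives a 1.1-fold lower number from compound 1 to compound 3 (0.05 log units; within the scatter). On this aromatic carbon of a five-membered aromatic ring with 2 nitrogen, the series now spans a much larger change than the earlier exchange of chloro for methoxy: the entering 3,4,5-trimethoxyphenyl has 12 heavy atoms and 3 hydrogen-bond acceptors, against 8 and 1 for the leaving 4-methoxyphenyl, yet the number in this assay stays within the scatter. The three compounds therefore give no order among these groups, and nothing available offers an explanation for this flat result.

From the compounds shown here alone, all three compounds keep a substituted phenyl ring at this position, so it remains open whether the read-out would respond to a group of another kind there, such as an amine, a carboxylic acid or a longer chain. The rest of the shared core is the same in all three compounds, so these data say nothing about how changes elsewhere would register.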